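Adding a Fluorine to a Thiosemicarbazone: What to Expect

A few compounds are considered here, and "the series" means these few. Any claim that something is new, unique, unknown or untested is made for them only; others in the source may bear on it.

Within the data shown here, compound 2 `N/C(=N\NC(=S)N1CCSCC1)c1ccccn1` gives 25.1% in a functional assay on HeLa cells (Homo sapiens) for cytotoxicity, read by MTT assay, with a stated time of 72 h, tested at 1 uM (a lower number here means less inhibition of growth, a higher number more inhibition of growth at the concentration tested), the lower of the two numbers known so far. Compound 1 `N/C(=N\NC(=S)N1CCCC1)c1ccc(F)cn1`, which carries a fluoro group and a different ring at the thiocarbonyl end, gives 62.8% in this assay. Compound 3 `N/C(=N\NC(=S)N1CCSCC1)c1ccc(F)cn1`, not yet measured, differs from compound 2 by fluoro in place of hydrogen on an aromatic carbon. Compound 1 differs from compound 2 in two places, and how much the fluoro group alone contributes cannot be read from these numbers. A rise beyond the scatter is nonetheless expected, a step of a number 14.9 percentage points higher from compound 2 to compound 3 (beyond the scatter). Compound 3 is estimated at 40%, within a range from 20% to 65%.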

Compound 3, percent growth inhibition at one concentration: 19.6%
Compound 3: the middle estimate sits 20.4 percentage points above what was measured, and the stated range ends above it.
By their numbers in this assay, from the lowest: compounds 3 and 2 (each within the scatter of the next); then compound 1.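

In this assay, fluoro in place of hydrogen on this aromatic carbon, para to a large group, gives a number 5.5 percentage points lower from compound 2 to compound 3 (within the scatter), so with thiomorpholin-4-yl in the molecule this change cannot be told from the scatter. With the fluoro group kept, thiomorpholin-4-yl in place of pyrrolidin-1-yl on the thiocarbonyl carbon gives a number 43.2 percentage points lower from compound 1 to compound 3 (beyond the scatter), so the large difference among these compounds goes with that ring. Nothing available explains either result. From the compounds shown here alone, whether fluoro matters alongside pyrrolidin-1-yl stays open. So does the effect of a chloro or methoxy group on this aromatic carbon, or of a piperidin-1-yl ring on the thiocarbonyl carbon.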